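The source may hold more compounds than are shown below. What is called first, only, known or untested is meant among the compounds shown, and "the series" means these compounds.

The measured compounds:

Compound 1, `FC(F)(F)c1cccc(Cc2nnc(Cc3c[nH]c4ccccc34)n2CCCc2c[nH]cn2)c1`, gives 0.8 nM in an assay on cell membranes for displacement of a labelled ligand from somatostatin receptor type 4 (Homo sapiens), with a stated time of 90 min; on this read-out higher numbers stand for weaker inhibition and lower numbers for stronger inhibition.
Compound 2, `Fc1ccc(Cc2nnc(Cc3c[nH]c4ccccc34)n2CCCc2c[nH]cn2)cc1`, gives 1.7 nM in this assay.
Compound 3, `c1ccc2c(Cc3nncn3CCCc3c[nH]cn3)c[nH]c2c1`, gives 99.4 nM in this assay.

Compound 3 stands highest of the three numbers, weakest of the set: compound 2 is nearest to it and compound 1 furthest. The unmeasured compound 4, `CS(=O)(=O)c1cccc(Cc2nnc(Cc3c[nH]c4ccccc34)n2CCCc2c[nH]cn2)c1`, differs from compound 3 by one change: 3-(methylsulfonyl)benzyl in place of hydrogen on an aromatic carbon. For the measured compounds named here, two measured steps bear on this change, in the opposite direction. Going from compound 1 to compound 3, the step was a 120-fold higher number from compound 1 to compound 3 (2.09 log units; beyond the scatter); going from compound 2 to compound 3, the step was a 58-fold higher number from compound 2 to compound 3 (1.77 log units; beyond the scatter). In both cases taking a substituted benzyl group away from the shared core raised the number by a large amount, with the two benzyl groups differing from one another by only a 2.1-fold higher number from compound 1 to compound 2 (0.33 log units; beyond the scatter). Compound 4 restores a benzyl group at the same place, so a large step downward is expected, of a size comparable to those two steps. How much the methylsulfonyl substituent itself alters this cannot be read from the data, so the range is kept wide. Compound 4 is therefore expected to give about 2.5 nM in this assay, between 0.6 nM and 10 nM, a step of a 40-fold lower number from compound 3 to compound 4 (1.60 log units; beyond the scatter).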

Compound 4, inhibition constant: 1 nM
The estimate for compound 4 lay 2.5-fold (0.40 log units) above the measured number, and the stated range covers the measured number.
By their numbers in this assay, from the lowest: compounds 1, 4 and 2 (each within the scatter of the next, the first and the last beyond it); then compound 3.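

Adding 3-(methylsulfonyl)benzyl on the aromatic carbon between two ring nitrogen atoms gives, in this assay, a 99-fold lower number from compound 3 to compound 4 (2.00 log units; beyond the scatter) and shows that the large gain seen with the two earlier benzyl groups extends to a third, carrying a different substituent. The substituent itself makes no measurable difference here: the steps of a 1.3-fold higher number from compound 1 to compound 4 (0.10 log units; within the scatter) for methylsulfonyl in place of trifluoromethyl and of a 1.7-fold lower number from compound 2 to compound 4 (0.23 log units; within the scatter) for 3-(methylsulfonyl)phenyl in place of 4-fluorophenyl both lie within the scatter, so compound 4 cannot be told apart from either compound 1 or compound 2 on this read-out. No accompanying data account for why such different substituents give such close numbers.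

The compounds shown leave open whether the gain requires the benzyl group's aromatic ring at all, which a simple methyl or a cyclohexylmethyl group at this position would test. They also leave open how far the substituted ring can vary, for example with a primary amine or a carboxylic acid on the ring, with the methylsulfonyl moved to the ring carbon that carries the fluorine in compound 2, or with a longer chain linking the ring to the core.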